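Sulfonyl chain variation: cyclopentyl to heptyl

This account rests on a few compounds, and the source may have more. Where it says the series, first, only, none or still open, it means among the compounds named here.

Among the measured compounds shown here, compound 3 `O=S(=O)(/C=C/c1ccc(O)c(O)c1)CC1CCCC1` gives 9400 nM in a functional assay, read by fluorescence and spectrophotometry, with a stated time of 1 h (a higher number here means that more compound is needed for the effect, a lower number that less compound is needed), the highest of the three numbers measured so far, though within the scatter of both compound 1 `O=S(=O)(/C=C/c1ccc(O)c(O)c1)CC1CCC1` at 8800 nM and compound 2 `CCCCCCCCCCCCS(=O)(=O)/C=C/c1ccc(O)c(O)c1` at 8500 nM. For the measured compounds named here, the only single-change step measured, a 1.1-fold higher number from compound 1 to compound 3 (0.03 log units; within the scatter), lies within the scatter. Compound 4 `CCCCCCCCS(=O)(=O)/C=C/c1ccc(O)c(O)c1` differs from compound 3 by heptyl in place of cyclopentyl on a saturated chain carbon bound to a sulfonyl sulfur. Going by the values given here, no measured step exchanges a ring for a chain at this position, but compound 2 carries a long chain there and its value sits with the others, and the ring-size step likewise changed nothing beyond the scatter. The step of a 1.1-fold lower number from compound 3 to compound 4 (0.03 log units; within the scatter) is therefore expected to stay within the scatter. Compound 4 is estimated at 8800 nM in this assay, ranging from 4400 nM to 17600 nM.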

Compound 4, half-maximal effective concentration: 6400 nM
Compound 4: middle estimate off by 1.4-fold (0.14 log units), on the high side; measured number inside the range.
By their numbers in this assay, from the lowest: compounds 4, 2, 1 and 3 (each within the scatter of the next).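

In this assay, among the compounds shown here, the first exchange of a ring for a chain on a saturated chain carbon bound to a sulfonyl sulfur stays within the scatter, whether the ring is cyclopentyl (a 1.5-fold lower number from compound 3 to compound 4 (0.17 log units; within the scatter)) or cyclobutyl (a 1.4-fold lower number from compound 1 to compound 4 (0.14 log units; within the scatter)). Shortening the chain also stays within the scatter (a 1.3-fold lower number from compound 2 to compound 4 (0.12 log units; within the scatter)). Nothing available bears on why these values stay so close. Still open, going by these compounds, is whether an amine or a carboxylic acid on this chain, or a chain as short as ethyl, would give a step beyond the scatter.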